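Bromo substitution carried onto the acetyl-bearing core

The source may report more compounds than this note shows. Statements on the series, on what has been measured and on what is new or still open speak of the compounds shown alone.

Compound 1 `Cn1cc(C2CCN=C(N)N2)c2ccccc21` and compound 2 `Cn1cc(C2CCN=C(N)N2)c2ccc(Br)cc21` share one core, while compound 3 `CC(=O)/N=C1\NCCC(c2cn(C)c3ccccc23)N1` has a different core; the difference between the two cores is not broken down here. In a functional assay on A549 cells (Homo sapiens) for cytotoxicity, read by sulforhodamine B assay, with a stated time of 72 h (on this read-out higher numbers stand for weaker inhibition of growth and lower numbers for stronger inhibition of growth), compound 1 gives 2670 nM and compound 2 gives 9110 nM. The change from compound 1 to compound 2 is bromo in place of hydrogen on an aromatic carbon and this step gave a 3.4-fold higher number from compound 1 to compound 2 (0.53 log units; beyond the scatter). In this assay compound 3 gives 10700 nM, which lies within the scatter of compound 2 and is the higher number against compound 1. Compound 4 `CC(=O)/N=C1\NCCC(c2cn(C)c3ccc(Br)cc23)N1` is not yet measured; its change from compound 3 is bromo in place of hydrogen on an aromatic carbon, the same change as that from compound 1 to compound 2. Compound 4 is expected to give 32000 nM in this assay, with a range of 12000 nM to 90000 nM. For compound 4 the expected step, a 3.0-fold higher number from compound 3 to compound 4 (0.48 log units; beyond the scatter), rests on the measured step of a 3.4-fold higher number from compound 1 to compound 2 (0.53 log units; beyond the scatter) applied to the value of compound 3, 10700 nM.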

Compound 4, concentration for 50% growth inhibition: 430 nM
Beside the measured number, compound 4's estimate is 74-fold (1.87 log units) above it; measured number below the stated range.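

On the core of compound 3, bromo in place of hydrogen on an aromatic carbon gave a 25-fold lower number from compound 3 to compound 4 (1.40 log units; beyond the scatter) in this assay. The same change therefore does not carry over between these two cores, and its direction reverses: the same change on two cores in this assay, a 3.4-fold higher number (0.53 log units; beyond the scatter) from compound 1 to compound 2 and a 25-fold lower number (1.40 log units; beyond the scatter) from compound 3 to compound 4, 85-fold (1.93 log units) apart, beyond the scatter of two such steps. Within the data shown here, this rests on one pair per core and shows only that the step depends on the core, not which feature of the core causes the difference or how any other substituent would behave.

Open, from the compounds shown here alone, is whether chloro or methoxy in place of bromo at this position would follow the same split between the two cores. Also open, going by these compounds, is whether an acyl group other than acetyl, such as benzoyl, would give the step seen with compound 4.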